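From 3-methylphenyl to 2-isopropylphenyl on the shared core

The source may hold more compounds than are shown below. What is called first, only, known or untested is meant among the compounds shown, and "the series" means these compounds.

Of the compounds shown here, three on the shared core have been read in a functional assay on Jurkat cells (Homo sapiens) for inhibition, read by CCK-8 assay, with a stated time of 48 h (a higher number here means a weaker inhibitor of growth, a lower number a stronger inhibitor of growth), so far. Compound 1 (`COc1cccc(CNc2nc(Nc3ccc(N4CCN(C)CC4)cn3)ncc2Cl)c1`) gives 73400 nM with 3-methoxybenzyl on the nitrogen. Compound 2 (`CN1CCN(c2ccc(Nc3ncc(Cl)c(NCc4ccco4)n3)nc2)CC1`) carries (furan-2-yl)methyl there and reads > 100000 nM as a limit of the assay, not a number. Compound 3 (`Cc1cccc(Nc2nc(Nc3ccc(N4CCN(C)CC4)cn3)ncc2Cl)c1`) gives 15300 nM with 3-methylphenyl on that nitrogen, the lowest number of the set.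

The furan swap shows an at least 1.3-fold higher number from compound 1 to compound 2 (0.13 log units; that floor lies within the scatter) and so tells little. Replacing either chain-linked group with 3-methylphenyl gives a 4.8-fold lower number from compound 1 to compound 3 (0.68 log units; beyond the scatter) and an at least 6.5-fold lower number from compound 2 to compound 3 (0.81 log units; beyond the scatter) in the same direction.

Compound 4 (`CC(C)c1ccccc1Nc1nc(Nc2ccc(N3CCN(C)CC3)cn2)ncc1Cl`) has 2-isopropylphenyl in place of 3-methylphenyl on a nitrogen on an aromatic ring. Among the compounds with values here, no measured step changes the groups on a phenyl attached this way, so the steps above bear on it only indirectly. Compound 4 keeps the phenyl on the nitrogen, so compound 3 at 15300 nM serves as the anchor in this assay and no step beyond the scatter is expected. The estimate means a 1.3-fold lower number from compound 3 to compound 4 (0.11 log units; within the scatter) as the expected change. Compound 4 is estimated at 12000 nM with an expected range of 4000 nM to 35000 nM for this read-out.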

Compound 4, concentration for 50% growth inhibition: 5140 nM
Compound 4: the middle estimate sits 2.3-fold (0.37 log units) above what was measured; the measured number falls inside the stated range.
By their numbers in this assay, from the lowest: compound 4; then compound 3; then compound 1. At a limit, above all of these: compound 2.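

In this assay, within the data shown here, a 3.0-fold lower number from compound 3 to compound 4 (0.47 log units; beyond the scatter) is the only step that changes the group on a phenyl attached to this nitrogen, and it lies beyond the scatter, so the substitution on that phenyl affects the read-out and not only the choice between a phenyl and a chain-linked ring. Compared with the chain-linked groups, 2-isopropylphenyl gives larger steps, with a 14-fold lower number from compound 1 to compound 4 (1.15 log units; beyond the scatter) and an at least 19-fold lower number from compound 2 to compound 4 (1.28 log units; beyond the scatter), which places compound 4 lowest of the four compounds in this assay. Compound 2 sits at a limit of the assay and not at a number, so its step gives only a floor: the limit of > 100000 nM in this assay, at which 1 of the 4 values shown sits.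

The step from 3-methylphenyl to 2-isopropylphenyl alters both the size of the alkyl group and its place on the phenyl, and these two compounds cannot separate one from the other. Also open, going by these compounds, is how the read-out responds to other groups on this phenyl, such as a methoxy group, an amine or a carboxylic acid, and whether the trend holds for a longer chain in place of the isopropyl group.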